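The source may report more compounds than this note shows. Statements on the series, on what has been measured and on what is new or still open speak of the compounds shown alone.

Working notes on the series. Of the compounds shown here, two have a number so far. Compound 1 `Nc1nccnc1C(=O)Nc1ccncc1` in an assay for inhibition of protein kinase C iota type (Homo sapiens), read by mobility shift assay, with a stated time of 60 min (on this read-out higher numbers stand for weaker inhibition and lower numbers for stronger inhibition), gives 23000 nM. Compound 2 `Nc1nccnc1C(=O)Nc1ccc2[nH]ccc2c1` in this assay gives 34000 nM. Within the data shown here, the two numbers lie within the scatter of one another, so compound 1 does not stand apart from compound 2 on what has been measured; no step between measured compounds that differ in a single place is available, and the two differ in the whole amide-linked aromatic part.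

The next compound to be measured is compound 3 `CCc1cc(NC(=O)c2nccnc2N)ccn1`. It keeps the core of compound 1 and differs from it in one place: ethyl in place of hydrogen on an aromatic carbon. Among the measured compounds shown here, no measured pair shows what such a change does, so the expectation rests on compound 1 alone and on the absence of any strong number among the two measured compounds.

The step from compound 1 to compound 3 in this assay is expected to be a 1.4-fold lower number from compound 1 to compound 3 (0.16 log units; within the scatter), that is, little beyond the scatter. For compound 3 in this assay the estimate is 16000 nM, with a range from 5000 nM to 50000 nM.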

Compound 3, half-maximal inhibitory concentration: 19600 nM
Beside the measured number, compound 3's estimate is 1.2-fold (0.09 log units) below it, and the stated range covers the measured number.
By their numbers in this assay, from the lowest: compounds 3, 1 and 2 (each within the scatter of the next).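

The ethyl step gives the series its first reading of a change in a single place: in this assay, ethyl in place of hydrogen on an aromatic carbon, next to the ring nitrogen and meta to a large group, gives a 1.2-fold lower number from compound 1 to compound 3 (0.07 log units; within the scatter). This position therefore accepts two added carbon atoms with no change that can be told from the scatter, and the hydrogen there is shown not to be required for the weak inhibition seen with compound 1. It also shows that ethyl at this position does not lift compound 3 clear of compound 1, while no measurement on hand bears on why the step is so small.

One alkyl group cannot show whether this position is insensitive in general or only to ethyl, so an amine, a carboxylic acid or a longer chain such as butyl at the same carbon would test how far that tolerance extends. Among these compounds, also open is whether a methoxy group or a chlorine atom on the other aromatic carbons of this ring would give a step beyond the scatter, which no step so far addresses.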